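A few compounds are considered here, and "the series" means these few. Any claim that something is new, unique, unknown or untested is made for them only; others in the source may bear on it.

Of the compounds shown here, three from one series have been tested in an ADME assay on BJ cells (Homo sapiens) for cytotoxicity, with a stated time of 72 h; a lower number here means that less compound is needed, a higher number that more compound is needed for the effect. Compound 1 `CCc1ccc(-c2nc3c(c(C)nn3-c3ccccc3)c(-c3ccccc3F)c2C#N)cc1` reached only a limit of the assay, giving > 20000 nM, which is a limit rather than a number. Compound 2 `CCc1ccc(-c2nc3c(c(C)nn3-c3ccccc3)c(-c3ccccc3C(=O)O)c2C#N)cc1`, with carboxy in place of fluoro on an aromatic carbon, likewise gave only a limit, > 20000 nM. The step that the two limits leave unreadable from compound 1 to compound 2 therefore cannot be read. For the measured compounds named here, compound 3 `Cc1ccc(-c2nc3c(c(C)nn3-c3ccccc3)c(-c3ccccc3O)c2C#N)cc1` is the one compound with a number: in this assay compound 3 gives 22200 nM, close to the limit of > 20000 nM in this assay, at which 2 of the 3 values shown sit. Compound 4 `Cc1nn(-c2ccccc2)c2nc(-c3ccc([N+](=O)[O-])cc3)c(C#N)c(-c3ccccc3O)c12` differs from compound 3 by nitro in place of methyl on an aromatic carbon. Going by the values given here, no measured step involves nitro in place of methyl on an aromatic carbon, and the only measured step is unreadable, so the expectation rests on compound 3 alone. The step in this assay is expected to be a 1.0-fold lower number from compound 3 to compound 4 (0.00 log units; within the scatter), that is, none beyond the scatter. Compound 4 is estimated at 22000 nM in this assay, within 10000 nM to 50000 nM, with a fair chance that only a limit is reported.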

Compound 4, half-maximal effective concentration: > 20000 nM
Compound 4 was reported as a limit; the forecaster's own chance of this, stated with the estimate: 40%; the middle value does not contradict the limit.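

In this assay compound 4 gives > 20000 nM, which is a limit and not a number, so the step from compound 3 to compound 4 cannot be read. Whether 4-nitrophenyl in place of 4-methylphenyl changes the number at all stays open, and the values shown offer little to compare: the limit of > 20000 nM in this assay, at which 3 of the 4 values shown sit.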